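Working notes: hydroxy to hydrogen on compound 2

A few compounds are considered here, and "the series" means these few. Any claim that something is new, unique, unknown or untested is made for them only; others in the source may bear on it.

In a functional assay on Hep 3B2 cells (Homo sapiens) for cytotoxicity, read by MTT assay, with a stated time of 48 h (a lower number here means a stronger inhibitor, a higher number a weaker inhibitor), compound 1 `COc1ccc2[nH]c(-c3ccc[se]3)cc(=O)c2c1OC` gives > 100000 nM, which is a limit of the assay and not a number. Among the compounds with values here, compound 2 `COc1ccc2[nH]c(-c3ccc[se]3)cc(=O)c2c1O` gives 700 nM in this assay and stands as the only number among the two values shown; the other value is the limit of > 100000 nM in this assay, at which 1 of the 2 values shown sits. Within the data shown here, the one measured step, an at least 140-fold lower number from compound 1 to compound 2 (2.15 log units; beyond the scatter), is the sole guide in this set.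

Compound 3 `COc1ccc2[nH]c(-c3ccc[se]3)cc(=O)c2c1` differs from compound 2 by hydrogen in place of hydroxy on an aromatic carbon. This is not the change that was measured: the measured step replaced a methyl on oxygen with hydrogen and gave a large gain, whereas here the hydroxy itself is removed. The measured step bears on it only indirectly: it shows that a change at this oxygen moves the number greatly, so removing the group entirely is expected to cost potency, most likely a large step toward a higher number in this assay, though the direction rests on a single pair. The expected step is a 17-fold higher number from compound 2 to compound 3 (1.23 log units; beyond the scatter). Compound 3 is expected to give 12000 nM, with a range from 1500 nM to 100000 nM.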

Compound 3, half-maximal inhibitory concentration: 3200 nM
For compound 3 the middle estimate is 3.8-fold (0.57 log units) above the measured one; measured number inside the range.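

Removing the hydroxy carries only a limited cost at this aromatic carbon, with a 4.6-fold higher number from compound 2 to compound 3 (0.66 log units; beyond the scatter) in this assay, so the hydroxy improves the number but is not needed for measurable activity. The larger effect at this position comes from the methoxy group: an at least 31-fold lower number from compound 1 to compound 3 (1.49 log units; beyond the scatter), which shows that hydrogen here is far better tolerated than methoxy and that the gain seen on going from methoxy to hydroxy does not depend on the hydroxy alone. The three compounds therefore rank hydroxy ahead of hydrogen and hydrogen ahead of methoxy at this one position, but the value of compound 1 is a limit of the assay and not a number, so the full size of the methoxy penalty stays undefined: the limit of > 100000 nM in this assay, at which 1 of the 3 values shown sits.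

The compounds shown leave open where other groups on this aromatic carbon would fall in that order, such as an amine, a fluorine atom or an ethoxy group. They also leave open whether the same order holds when the methoxy group ortho to this carbon is changed, or on a core other than the shared one.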